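The compounds below may be only part of what the source reports. "The series", "measured", "known", "first", "only" and "open" are said of these compounds alone.

Within the data shown here, compound 2 `Cc1ccc2nc(-c3ccccc3F)[nH]c(=O)c2c1` gives 36.3% in an assay on isolated protein for inhibition of DNA topoisomerase 1 (Homo sapiens), with a stated time of 30 min, tested at 20 uM (a higher number here means a stronger effect of the compound at the concentration tested, a lower number a weaker effect), the higher of the two numbers known; compound 1 `Cc1ccc2nc(-c3ccccc3C(F)(F)F)[nH]c(=O)c2c1` gives 21.1%. Among the measured compounds shown here, the single measured step, a number 15.2 percentage points higher from compound 1 to compound 2 (beyond the scatter), is the only guide available. Compound 3 `Cc1ccc2nc(-c3ccccc3OC(F)(F)F)[nH]c(=O)c2c1` carries a (trifluoromethoxy in place of fluoro on an aromatic carbon). Because the step of a number 15.2 percentage points higher from compound 1 to compound 2 (beyond the scatter) was modest but beyond the scatter, and compound 3 returns to a fluorinated substituent of the kind found in compound 1, a fall of similar size is expected rather than a gain. Compound 3 is therefore expected to give 24%, within 10% to 40%, a step of a number 12.3 percentage points lower from compound 2 to compound 3 (beyond the scatter).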

Compound 3, a percentage reported as inhibition, at one concentration (the size of the read-out at that concentration, not a potency): 0%
Estimate against measurement, compound 3: 24 percentage points above; measured number below the stated range.
By their numbers in this assay, from the lowest: compound 3; then compound 1; then compound 2.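

On an aromatic carbon ortho to a large group, the fluorinated substituents are clearly not interchangeable in this assay: trifluoromethoxy in place of fluoro gives a number 36.3 percentage points lower from compound 2 to compound 3 (beyond the scatter), and trifluoromethoxy in place of trifluoromethyl gives a number 21.1 percentage points lower from compound 1 to compound 3 (beyond the scatter). The earlier compounds shown here showed only a modest difference at this position, whereas these steps show that a single change there can take the read-out down to nothing. Nothing available explains this result. As far as these compounds go, whether a methoxy group, an amine or a carboxylic acid at this place would restore or raise the effect remains open.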